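Ring-nitrogen substituent and tolerated concentration on canine cells

The source may hold more compounds than are shown below. What is called first, only, known or untested is meant among the compounds shown, and "the series" means these compounds.

The series shares one core and varies only the group on the amine nitrogen in a ring. Compound 1 `COC(=O)C[C@H](NC(=O)OC(C)(C)C)C(=O)N(Cc1ccc(F)cc1)C1(C(=O)NCc2ccccc2)CCN(Cc2ccccc2)CC1` carries benzyl there; in an ADME assay on MDCK cells (Canis lupus familiaris) for cytotoxicity, read by microscopy, with a stated time of 72 h (a lower number here means that less compound is tolerated, a higher number that more compound is tolerated), compound 1 reaches only the limit > 100000 nM. Compound 2 `COC(=O)C[C@H](NC(=O)OC(C)(C)C)C(=O)N(Cc1ccc(F)cc1)C1(C(=O)NCc2ccccc2)CCNCC1` carries hydrogen, and in this assay compound 2 gives 100000 nM. Compound 3 `COC(=O)C[C@H](NC(=O)OC(C)(C)C)C(=O)N(Cc1ccc(F)cc1)C1(C(=O)NCc2ccccc2)CCN(C2CCCCC2)CC1` carries cyclohexyl, and in this assay compound 3 gives 73000 nM, which stands as the lowest of the two plain numbers shown, with compound 2 nearest and within the scatter of it. The steps measured so far are a number no higher from compound 1 to compound 2 (the limit leaves the size open), an at least 1.3-fold lower number from compound 1 to compound 3 (0.13 log units; that floor lies within the scatter) and a 1.4-fold lower number from compound 2 to compound 3 (0.14 log units; within the scatter); none of them is beyond the scatter, and the first of them is left open because of the limit (the limit of > 100000 nM in this assay, at which 1 of the 3 values shown sits). Compound 4 `COC(=O)C[C@H](NC(=O)OC(C)(C)C)C(=O)N(Cc1ccc(F)cc1)C1(C(=O)NCc2ccccc2)CCN(c2ccccc2)CC1` is not yet measured; it differs from compound 3 by phenyl in place of cyclohexyl on an amine nitrogen in a ring. Both steps at this position that carry a number were small, so a step within the scatter in either direction is expected for a 1.1-fold higher number from compound 3 to compound 4 (0.04 log units; within the scatter). Compound 4 is therefore estimated at 80000 nM, spanning 40000 nM to 130000 nM, with a real chance that only the limit is reported.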

Compound 4, minimum cytotoxic concentration: 20000 nM
Compound 4: the middle estimate sits 4.0-fold (0.60 log units) above what was measured; the whole stated range lies above it.
By their numbers in this assay, from the lowest: compound 4; then compounds 3 and 2 (each within the scatter of the next).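

In this assay, this position gives its first steps beyond the scatter: a 3.7-fold lower number from compound 3 to compound 4 (0.56 log units; beyond the scatter), although phenyl and cyclohexyl match in heavy-atom count and differ in that the ring is aromatic. Phenyl also separates compound 4 from the other two compounds, with a 5.0-fold lower number from compound 2 to compound 4 (0.70 log units; beyond the scatter) and an at least 5.0-fold lower number from compound 1 to compound 4 (0.69 log units; beyond the scatter), so an aromatic ring alone does not account for the shift, since benzyl in compound 1 also carries one and goes against that reading. The step from compound 1 is only a floor, as compound 1 is held at a limit: the limit of > 100000 nM in this assay, at which 1 of the 4 values shown sits.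

From the compounds shown here alone, what remains open is whether the lower number follows any aromatic ring set on the amine nitrogen or phenyl alone. A pyridyl ring or a methoxyphenyl group at this position would test that.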